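Removing the hydroxymethyl from compound 3

A few compounds are considered here, and "the series" means these few. Any claim that something is new, unique, unknown or untested is made for them only; others in the source may bear on it.

The series pairs a fluorophenyl alkyne with a shared core carrying one variable group. Compound 1 `Cc1nc(C#Cc2cccc(F)c2)cs1` bears a methyl there; in a functional assay on CHO cells for agonist activity at metabotropic glutamate receptor 5 (Homo sapiens), read by inositol phosphate accumulation (on this read-out higher numbers stand for weaker inhibition and lower numbers for stronger inhibition), compound 1 gives 23 nM. Compound 2 `Fc1cccc(C#Cc2csc(Br)n2)c1` carries a bromo in the same position, and in this assay compound 2 gives 526 nM; that exchange yields a 23-fold higher number from compound 1 to compound 2 (1.36 log units; beyond the scatter). Compound 3 `OCC#Cc1nc(C#Cc2cccc(F)c2)cs1` carries a 3-hydroxyprop-1-yn-1-yl in place of the methyl. In this assay compound 3 reaches only the limit of the assay, > 10000 nM, and no number is known for it. Against compound 1 this is an at least 430-fold higher number from compound 1 to compound 3 (2.63 log units; beyond the scatter), and against compound 2 it is an at least 19-fold higher number from compound 2 to compound 3 (1.27 log units; beyond the scatter); compound 3 is the one value sitting at the limit of > 10000 nM in this assay, at which 1 of the 3 values shown sits.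

Compound 4 `C#Cc1nc(C#Cc2cccc(F)c2)cs1` differs from compound 3 by hydrogen in place of hydroxymethyl on a triple-bonded carbon. For the measured compounds named here, no measured step covers this exact change. The two steps into compound 3 show that the full 3-hydroxyprop-1-yn-1-yl arm pushes the number past the limit, while methyl and bromo stay measurable; compound 4 keeps part of that arm as ethynyl. The expected step is an at least 6.6-fold lower number from compound 3 to compound 4 (0.82 log units; beyond the scatter), a partial return toward measurable inhibition, with wide uncertainty. Compound 4 is therefore estimated at 1500 nM, expected to fall between 200 nM and 10000 nM.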

Compound 4, half-maximal inhibitory concentration: 2920 nM
Estimate against measurement, compound 4: 1.9-fold (0.29 log units) below; measured number inside the range.
By their numbers in this assay, from the lowest: compound 1; then compound 2; then compound 4. At a limit, above all of these: compound 3.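

Taking off the hydroxymethyl brings the arm back to a measurable number in this assay, with an at least 3.4-fold lower number from compound 3 to compound 4 (0.53 log units; beyond the scatter). Compound 3 holds only a limit and not a number, so this step gives a bound and not a size: the limit of > 10000 nM in this assay, at which 1 of the 4 values shown sits. The ethynyl arm still does not match the smaller groups on this aromatic carbon, with a 5.6-fold higher number from compound 2 to compound 4 (0.74 log units; beyond the scatter) and a 130-fold higher number from compound 1 to compound 4 (2.10 log units; beyond the scatter), so part of the rise from methyl belongs to ethynyl alone and the remainder, of unknown size, to the hydroxymethyl.

Still open, on these data alone, is how much of the rise with ethynyl rests on the triple bond itself, and an ethyl on the same aromatic carbon would separate that from the added length of the group. Also open, as far as these compounds go, is whether the carbon or the oxygen of the hydroxymethyl carries the further rise, and a methyl or an aminomethyl on the triple-bonded carbon would set these apart.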